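This account rests on a few compounds, and the source may have more. Where it says the series, first, only, none or still open, it means among the compounds named here.

The series rests on a shared core carrying a pyridyl group and a diaryl urea, and its members were tested in a functional assay on CCRF-CEM cells (Homo sapiens) for inhibition, read by sulforhodamine B assay, with a stated time of 48 h; a lower number here means a stronger inhibitor of growth, a higher number a weaker inhibitor of growth. Compound 1 `O=C(Nc1cccc(-n2cc(-c3ccncc3)c(-c3ccc(Cl)c(O)c3)n2)c1)Nc1cccc(C(F)(F)F)c1` gives 1400 nM in this assay. Within the data shown here, compound 2 `COc1cc(-c2nn(-c3cccc(NC(=O)Nc4ccc(Cl)c(Cl)c4)c3)cc2-c2ccncc2)ccc1Cl` gives 1040 nM in this assay, the lower of the two numbers known so far, though its gap to compound 1 lies within the scatter of repeated measurements, so no order between them can be claimed. Compound 3 `O=C(Nc1cccc(-n2cc(-c3ccncc3)c(-c3ccc(Cl)c(O)c3)n2)c1)Nc1ccc(Cl)c(Cl)c1` is not yet measured. It differs from compound 2 in one place: hydrogen in place of methyl on an oxygen on an aromatic ring. Among the measured compounds shown here, no measured pair shows this change alone, so its effect is unknown. Since compound 1 already carries the hydroxy group and gives 1400 nM, a step of no real size beyond the scatter is expected, in either direction. The estimate for compound 3 is therefore 1200 nM in this assay, with a range from 500 nM to 3000 nM, which corresponds to an expected step of a 1.2-fold higher number from compound 2 to compound 3 (0.06 log units; within the scatter).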

Compound 3, concentration for 50% growth inhibition: 1030 nM
Compound 3: middle estimate off by 1.2-fold (0.07 log units), on the high side; measured number inside the range.
By their numbers in this assay, from the lowest: compounds 3, 2 and 1 (each within the scatter of the next).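

Among these compounds, the first readable pair at this oxygen, methoxy to hydroxy on the 4-chloro-3-methoxyphenyl group, shows a 1.0-fold lower number from compound 2 to compound 3 (0.00 log units; within the scatter) in this assay, so the two groups cannot be told apart at this position. With the hydroxy group held, 3,4-dichlorophenyl in place of 3-(trifluoromethyl)phenyl on an amide-type nitrogen shows a 1.4-fold lower number from compound 1 to compound 3 (0.13 log units; within the scatter), so these two groups cannot be told apart in this series either. Nothing measured here offers an explanation for these results.

On these data alone, all three compounds lie within the scatter of one another, so what would move the number remains open. As far as these compounds go, it is unknown whether an ethoxy group or a longer chain on this oxygen, an amine in its place, or a carboxylic acid on the phenyl ring of the urea would give a step beyond the scatter.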